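Saturating and Converting the Acrylamide of a CDK8 Inhibitor

This account rests on a few compounds, and the source may have more. Where it says the series, first, only, none or still open, it means among the compounds named here.

Three compounds share one core carrying a carbonyl-bearing side chain. Compound 1 `CN1CCN(C(=O)/C=C/c2ccncc2-c2ccc3ccccc3c2)CC1` gives 43.6 nM in an assay on a protein complex for inhibition of CDK8/Cyclin C (Homo sapiens), with a stated time of 1 h; on this read-out lower numbers stand for stronger inhibition and higher numbers for weaker inhibition. Among the measured compounds shown here, compound 2 `CNC(=O)/C=C/c1ccncc1-c1ccc2ccccc2c1` gives 12.4 nM in this assay, which places it at the lowest of the two numbers so far, and the step of a 3.5-fold lower number from compound 1 to compound 2 (0.55 log units; beyond the scatter) shows a modest but real gain when the amide substituent is changed. Compound 3 `O=C(O)[C@@H]1CCCN1C(=O)/C=C/c1ccncc1-c1ccc2ccccc2c1` gives "not determined" (no result reported) in this assay, so no number is available for it.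

Compound 4 `NNC(=O)CCc1ccncc1-c1ccc2ccccc2c1` differs from compound 2 in one place: 2-(aminocarbamoyl)ethyl in place of 2-(methylcarbamoyl)ethenyl on an aromatic carbon. For the measured compounds named here, the one measured step, from compound 1 to compound 2, concerned only the group on the carbonyl carbon and left the ethenyl linker untouched, so it says little about what happens when that linker is saturated and the amide becomes a hydrazide. The change in compound 4 touches the unsaturated part of the side chain that is common to compound 1 and compound 2, whereas a 3.5-fold lower number from compound 1 to compound 2 (0.55 log units; beyond the scatter) varied only the terminal group. The direction of the step in this assay is expected to be towards a higher number, of uncertain size. Compound 4 is therefore estimated at 70 nM, within a range of 14 nM to 350 nM, an expected step of a 5.6-fold higher number from compound 2 to compound 4 (0.75 log units; beyond the scatter) from compound 2 to compound 4.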

Compound 4, half-maximal inhibitory concentration: 7.7 nM
Compound 4: the middle estimate sits 9.1-fold (0.96 log units) above what was measured; the measured number lies below the stated range.
By their numbers in this assay, from the lowest: compounds 4 and 2 (each within the scatter of the next); then compound 1.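

The change of 2-(methylcarbamoyl)ethenyl to 2-(aminocarbamoyl)ethyl, on the aromatic carbon opposite the ring nitrogen, gives a 1.6-fold lower number from compound 2 to compound 4 (0.21 log units; within the scatter) in this assay, so the two compounds cannot be told apart on this read-out. Unlike the earlier step, which varied only the group on the carbonyl carbon, this one shows that the side chain at this position can lose its ethenyl double bond and take a hydrazide terminus, with 2 hydrogen-bond donors in place of 1, without the number moving beyond the scatter. No measurement bears on why the number holds across this change, so the result stands without an explanation.

Two changes travel together in this single step, so the compounds shown leave open whether saturation and the hydrazide would each hold alone, or whether opposing effects happen to cancel, a question that a methylamide on the saturated ethyl chain and a hydrazide on the ethenyl chain would separate. Going by these compounds, it also stays open how far the saturated chain can be pushed, for instance with a longer chain or with a primary amine in place of the hydrazide.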